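This account rests on a few compounds, and the source may have more. Where it says the series, first, only, none or still open, it means among the compounds named here.

Measured compounds in a functional assay on L1210 cells (Mus musculus) for cytotoxicity, with a stated time of 48 h; on this read-out lower numbers stand for stronger inhibition and higher numbers for weaker inhibition:
- compound 1 `Fc1ccc(-c2cn3nc(Cc4ccc(Cl)cc4)sc3n2)cc1`: > 250000 nM
- compound 2 `COc1ccc(-c2cn3nc(Cl)sc3n2)cc1`: 38000 nM

Compound 1 sits at the limit of > 250000 nM in this assay, at which 1 of the 2 values shown sits, which is a limit of the assay and not a number. Compound 2 returns a number; the two compounds differ in more than one place, so only their two values can be set side by side. Compound 3 `O=[N+]([O-])c1ccc(-c2cn3nc(Cc4ccc(Cl)cc4)sc3n2)cc1` is not yet measured. It differs from compound 1 by nitro in place of fluoro on an aromatic carbon, para to a large group. Within the data shown here, no measured pair shows the weight of such a change, so the expected step of an at least 1.2-fold lower number from compound 1 to compound 3 (0.09 log units; that floor lies within the scatter) in this assay is small, toward stronger inhibition if anything, and may not exceed the scatter. Compound 3 is therefore estimated at 200000 nM, with a range from 50000 nM to 400000 nM, and a fair chance that again only a limit is returned.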

Compound 3, half-maximal inhibitory concentration: 214000 nM
Estimate against measurement, compound 3: 1.1-fold (0.03 log units) below; the measured number falls inside the stated range.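

Placed on an aromatic carbon, para to a large group, nitro in place of fluoro gives in this assay an at least 1.1-fold lower number from compound 1 to compound 3 (0.06 log units; that floor lies within the scatter), the first reading of any change at this position. Compound 3 returns a number, 214000 nM, so this side of the pair is now fixed, and the change has not been shown to move the value beyond the scatter. Compound 1 remains a limit of the assay and not a number, which leaves only a floor for the step: the limit of > 250000 nM in this assay, at which 1 of the 3 values shown sits.

As far as these compounds go, the true size of this step stays open, as does whether it would hold on a compound that returns numbers on both sides. Also open, from the compounds shown here alone, is whether an amine or a carboxylic acid in the same place would give a step beyond the scatter.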